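Methylating the amide nitrogen of compound 1

This account rests on a few compounds, and the source may have more. Where it says the series, first, only, none or still open, it means among the compounds named here.

Among the compounds with values here, compound 1 `Cc1cccc(CNC(=O)c2nn(-c3ccc(F)cc3)c(OC[C@@H](O)C[C@@H](O)CC(=O)O)c2C(C)C)c1` is the only compound here with a number: in a functional assay on L6 cells (Rattus norvegicus) for inhibition (on this read-out higher numbers stand for weaker inhibition and lower numbers for stronger inhibition), compound 1 gives 280 nM. Compound 2 `CC(C)c1c(C(=O)NCc2ccc(Cl)cc2)nn(-c2ccc(F)cc2)c1OC[C@@H](O)C[C@@H](O)CC(=O)O` has no reported result in this assay: for compound 2 the entry reads "not determined" (no result reported). Compound 3 `Cc1cccc(CN(C)C(=O)c2nn(-c3ccc(F)cc3)c(OC[C@@H](O)C[C@@H](O)CC(=O)O)c2C(C)C)c1` differs from compound 1 in one place: methyl in place of hydrogen on an amide-type nitrogen. Within the data shown here, no measured pair shows this change, so its size is unknown from the data. Weaker inhibition is expected in this assay for compound 3, with the step of a 5.4-fold higher number from compound 1 to compound 3 (0.73 log units; beyond the scatter) lying beyond the scatter. For compound 3 the estimate in this assay is 1500 nM, with a range from 400 nM to 6000 nM.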

Compound 3, half-maximal inhibitory concentration: 18500 nM
For compound 3 the middle estimate is 12-fold (1.09 log units) below the measured one, and the stated range ends below it.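

At this amide-type nitrogen, methyl in place of hydrogen is far from neutral: in this assay the change gives a 66-fold higher number from compound 1 to compound 3 (1.82 log units; beyond the scatter), a large loss of inhibition. This makes the nitrogen a sensitive position on the core of compound 1, where a single added carbon is enough to weaken inhibition well beyond the scatter. Nothing in the data shown accounts for the size of this step. From the compounds shown here alone, it remains open whether an ethyl group or a longer chain on this nitrogen would behave like methyl. Also open, going by these compounds, is whether the loss holds when the 3-methylbenzyl group is replaced.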